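The source may hold more compounds than are shown below. What is called first, only, known or untested is meant among the compounds shown, and "the series" means these compounds.

The series shares the core of compound 1 `CNC(=O)c1cccc(NC(=O)N2CCC(Oc3ccccc3Cl)CC2)c1`. In an assay on isolated protein for inhibition of acyl-CoA desaturase 1 (Mus musculus) (on this read-out lower numbers stand for stronger inhibition and higher numbers for weaker inhibition), compound 1 gives < 4 nM, which is a limit of the assay and not a number. Compound 2 `Cc1noc(-c2cccc(NC(=O)N3CCC(Oc4ccccc4Cl)CC3)c2)n1` differs from it in one place; in this assay compound 2 gives 8 nM. That is the only number shown in this assay, so compound 2 stands as the sole measured value, the other entry being a limit. Among the measured compounds shown here, the one measured step, an at least 2.0-fold higher number from compound 1 to compound 2 (0.30 log units; that floor lies within the scatter), rests on (the limit of < 4 nM in this assay, at which 1 of the 2 values shown sits), so its true size remains open.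

Compound 3 `O=C(Nc1cccc(-c2ncc[nH]2)c1)N1CCC(Oc2ccccc2Cl)CC1` is not yet measured. It differs from compound 2 as follows: 1H-imidazol-2-yl in place of 3-methyl-1,2,4-oxadiazol-5-yl on an aromatic carbon. For the measured compounds named here, only the step from compound 1 to compound 2 bears on this kind of change at this position, and that step is known only at its floor, which lies within the scatter. On that basis no step beyond the scatter is expected in this assay from compound 2 to compound 3, estimated as a 1.3-fold higher number from compound 2 to compound 3 (0.10 log units; within the scatter). For compound 3 the value in this assay is expected to be 10 nM, within 3 nM to 35 nM.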

Compound 3, half-maximal inhibitory concentration: 10 nM
Estimate against measurement, compound 3: no gap at the digits printed; the range from low to high includes it.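

In this assay the exchange of 3-methyl-1,2,4-oxadiazol-5-yl for 1H-imidazol-2-yl gives a 1.3-fold higher number from compound 2 to compound 3 (0.10 log units; within the scatter), so on this aromatic carbon, meta to a large group, the two five-membered aromatic rings are not told apart, although their counts of hetero atoms, hydrogen-bond donors and hydrogen-bond acceptors differ. The series now also holds a step beyond the scatter, an at least 2.5-fold higher number from compound 1 to compound 3 (0.39 log units; beyond the scatter), which sets methylcarbamoyl apart from 1H-imidazol-2-yl at this place, something the floor of the earlier step within the scatter could not do. The value of compound 1 is a limit of the assay and not a number, so this step is known only as a floor: the limit of < 4 nM in this assay, at which 1 of the 3 values shown sits.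

Still open, as far as these compounds go, is whether the ring hydrogen on nitrogen plays any part, which a 1-methylimidazol-2-yl group at this place would address. Also open, from the compounds shown here alone, is how a carboxylic acid, an aminomethyl group or a longer amide such as ethylcarbamoyl would compare with methylcarbamoyl and the two five-membered rings on the shared core.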